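Compound 3 and the step to compound 4

A few compounds are considered here, and "the series" means these few. Any claim that something is new, unique, unknown or untested is made for them only; others in the source may bear on it.

compound 1 `COc1cc(NC(C)CCCN2C(=O)[C@H](C)NC2(C)C)c2ncccc2c1`: 71000 nM
compound 2 `COc1cc(NC(C)CCCN2C(=O)CN(C(C)=O)C2(C)C)c2ncccc2c1`: 60000 nM
compound 3 `COc1cc(NC(C)CCCNC(=O)CN2C(=O)[C@H](C)NC2(C)C)c2ncccc2c1`: 58000 nM

In a functional assay on Caco-2 cells (Homo sapiens) for antiproliferative activity, read by sulforhodamine B assay, with a stated time of 48 h (on this read-out higher numbers stand for weaker inhibition and lower numbers for stronger inhibition), compound 3 gives 58000 nM and stands level with the other two, all three lying within the usual scatter of one another. For the measured compounds named here, compound 4 `COc1cc(NC(C)CCCNC(C)=O)c2ncccc2c1` carries hydrogen in place of 2,2,4-trimethyl-5-oxoimidazolidin-1-yl on a saturated chain carbon bound to a carbonyl carbon as its one change. Going by the values given here, no measured pair differing in one place shows what such a change does, so only a small move toward weaker inhibition is expected, possibly none beyond the scatter. The estimated step is a 1.4-fold higher number from compound 3 to compound 4 (0.14 log units; within the scatter) and no more. For compound 4 the estimated value is 80000 nM with 35000 nM to 180000 nM as the expected span.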

Compound 4, half-maximal inhibitory concentration: 46000 nM
Compound 4: the middle estimate sits 1.7-fold (0.24 log units) above what was measured; the measured number falls inside the stated range.
By their numbers in this assay, from the lowest: compounds 4, 3, 2 and 1 (each within the scatter of the next).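

In this assay, hydrogen in place of 2,2,4-trimethyl-5-oxoimidazolidin-1-yl on a saturated chain carbon bound to a carbonyl carbon gives a 1.3-fold lower number from compound 3 to compound 4 (0.10 log units; within the scatter) and so leaves the result level, which shows that the ring group adds nothing measurable at this position. Acetamido in place of the same ring group on the saturated chain carbon gives a 1.5-fold lower number from compound 1 to compound 4 (0.19 log units; within the scatter) and likewise leaves the result level. No measurement on hand explains why these changes leave the result level.

On these data alone, whether an amine or a carboxylic acid at this place would move the number beyond the scatter stays open. So does the effect of a longer chain.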